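Cyclopropyl for cyclobutyl: a cytotoxicity limit awaits a value

This account rests on a few compounds, and the source may have more. Where it says the series, first, only, none or still open, it means among the compounds named here.

Compound 1 `CC(C)CCn1nc(-c2cccs2)c(O)c(C2=NS(=O)(=O)c3cc(CS(C)(=O)=O)ccc3N2)c1=O`: > 33000 nM (a limit)
Compound 2 `CS(=O)(=O)Nc1ccc2c(c1)S(=O)(=O)N=C(c1c(O)c(-c3cccs3)nn(CC3CCC3)c1=O)N2`: > 1000 nM (a limit)

In an ADME assay on Huh-7 cells (Homo sapiens) for cytotoxicity, with a stated time of 72 h (on this read-out lower numbers stand for higher toxicity in this test and higher numbers for lower toxicity in this test), compound 2 stands at > 1000 nM as a limit of the assay and not a number. Compound 1 gives > 33000 nM and that too is only a limit. Compound 3 `CS(=O)(=O)Nc1ccc2c(c1)S(=O)(=O)N=C(c1c(O)c(-c3cccs3)nn(CC3CC3)c1=O)N2` carries cyclopropyl in place of cyclobutyl on a saturated chain carbon bound to an aromatic nitrogen and is otherwise the same as compound 2. Going by the values given here, no measured step bears on this change, so the expectation is loose. The expected step that the limit leaves unreadable from compound 2 to compound 3 runs toward higher numbers, meaning no added toxicity. Expected for compound 3 is 5000 nM with 1000 nM to 33000 nM as its range.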

Compound 3, half-maximal cytotoxic concentration: > 1000 nM
Compound 3 was reported as a limit; the forecaster's own chance of this, stated with the estimate: 85%; the middle value lies beyond the limit too.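

Compound 2 gives > 1000 nM, which is a limit. Going by these compounds alone, compound 3 gives > 1000 nM, also a limit, so no step between the two can be read. On these data alone, whether cyclopropyl in place of cyclobutyl changes the result in this assay stays open.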